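A Cyclopropyl Ethenyl Amide Replaces the Hydrazide Chain

The compounds below may be only part of what the source reports. "The series", "measured", "known", "first", "only" and "open" are said of these compounds alone.

Measured so far:
compound 1, `NNC(=O)CCc1ccncc1-c1ccc2ccccc2c1`, 7.7 nM
compound 2, `CNC(=O)/C=C/c1ccncc1-c1ccc2[nH]ccc2c1`, 51.9 nM

Both numbers come from an assay on a protein complex for inhibition of CDK8/Cyclin C (Homo sapiens), with a stated time of 1 h; on this read-out higher numbers stand for weaker inhibition and lower numbers for stronger inhibition. Going by the values given here, compound 1 stands lowest of the two values in this assay with 7.7 nM; its only neighbour, compound 2, gives 51.9 nM, a higher number, and the gap between the two lies beyond the usual scatter.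

Compound 3, `O=C(/C=C/c1ccncc1-c1ccc2ccccc2c1)NC1CC1`, has not yet been measured. It differs from compound 1 in one place: 2-(cyclopropylcarbamoyl)ethenyl in place of 2-(aminocarbamoyl)ethyl on an aromatic carbon. Among the compounds with values here, no step between measured compounds isolates this change. Compound 2 carries a related ethenyl amide but a different aromatic group, so its value in this assay cannot be carried over directly, while compound 3 retains the aromatic portion of compound 1. The step is therefore expected to be small, within the scatter, as a 1.6-fold higher number from compound 1 to compound 3 (0.19 log units; within the scatter). The estimate for compound 3 in this assay is 12 nM, ranging from 4 nM to 40 nM.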

Compound 3, half-maximal inhibitory concentration: 40.1 nM
Beside the measured number, compound 3's estimate is 3.3-fold (0.52 log units) below it; measured number outside the range, above it.
By their numbers in this assay, from the lowest: compound 1; then compounds 3 and 2 (each within the scatter of the next).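

In this assay, placing 2-(cyclopropylcarbamoyl)ethenyl instead of 2-(aminocarbamoyl)ethyl on the aromatic carbon opposite the ring nitrogen gives a 5.2-fold higher number from compound 1 to compound 3 (0.72 log units; beyond the scatter), which shows that inhibition at this position responds to the change of this chain on the core of compound 1. The exchange alters several features at once: the entering group differs in its three-membered ring, its double bonds, and its hydrogen-bond donors and acceptors. No available evidence accounts for the step.

The compounds shown do not separate the ethenyl link from the cyclopropylcarbamoyl end, so either or both may carry the step. On these data alone, how this position would respond to a carboxylic acid, an amine or a longer chain also remains open.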